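The source may report more compounds than this note shows. Statements on the series, on what has been measured and on what is new or still open speak of the compounds shown alone.

Measured compounds:
- compound 1 `CCOC(=O)C1=Cc2ccccc2OC1(OCc1cn(-c2ccc(C)cc2)nn1)C(F)(F)F` in a functional assay on DU-145 cells (Homo sapiens) for inhibition, read by MTT assay, with a stated time of 24 h; on this read-out higher numbers stand for weaker inhibition and lower numbers for stronger inhibition: compound 1 gives 30200 nM
- compound 2 `CCOC(=O)C1=Cc2ccccc2OC1(OCc1cc(-c2ccc(Br)cc2)no1)C(F)(F)F`: in this assay compound 2 gives 71700 nM

Compound 1 holds the lowest of the two numbers shown; compound 2 sits at a higher number, and the gap between the two lies beyond the usual scatter of the measurement. For the measured compounds named here, both compounds share the same core and differ in the five-membered ring and its aryl group, and no single-point step between them is on record, so their two values only show that compound 1 is the stronger of the pair.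

The unmeasured compound 3 `CCOC(=O)C1=Cc2ccccc2OC1(OCc1cn(CC(=O)Nc2ccc(OC)cc2)nn1)C(F)(F)F` is reached from compound 1 by one change: ((4-methoxyphenyl)carbamoyl)methyl in place of 4-methylphenyl on an aromatic nitrogen. The aryl group on the aromatic nitrogen gives way to a ((4-methoxyphenyl)carbamoyl)methyl group. Nothing measured here tells how such a change acts in this assay, so the expectation is for no step beyond the scatter, with the chance of a modest move in either direction. The step from compound 1 to compound 3 is therefore expected to be a 1.2-fold higher number from compound 1 to compound 3 (0.06 log units; within the scatter). For compound 3 the estimate in this assay is 35000 nM, within a range of 10000 nM to 110000 nM.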

Compound 3, half-maximal inhibitory concentration: 32700 nM
The estimate for compound 3 lay 1.1-fold (0.03 log units) above the measured number, and the stated range covers the measured number.
By their numbers in this assay, from the lowest: compounds 1 and 3 (each within the scatter of the next); then compound 2.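

In this assay, putting ((4-methoxyphenyl)carbamoyl)methyl in place of 4-methylphenyl on the aromatic nitrogen gives a 1.1-fold higher number from compound 1 to compound 3 (0.03 log units; within the scatter), so this position accepts a group of 12 heavy atoms instead of 7, bringing a hydrogen-bond donor and two hydrogen-bond acceptors, with no shift beyond the scatter. The earlier pair could not show this, since its members differ in both the five-membered ring and its aryl group, whereas this step isolates a single place on the triazole-bearing side of the shared core. Nothing available accounts for why the two values stay level.

The compounds shown leave open whether this tolerance holds for other kinds of group on the same aromatic nitrogen, such as a carboxylic acid, an amine or a plain alkyl chain, any of which could move the value in this assay. They also leave open how much the methoxy group in the entering group contributes, and whether a hydroxy group or a chlorine atom in its place would leave the number where it stands.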